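The source may report more compounds than this note shows. Statements on the series, on what has been measured and on what is new or still open speak of the compounds shown alone.

Of the compounds shown here, two have so far been measured in an assay on isolated protein for inhibition of Rho-associated protein kinase 2 (Homo sapiens), read by a luciferase reporter; on this read-out lower numbers stand for stronger inhibition and higher numbers for weaker inhibition. Compound 1, `O=C(Nc1cc2cc[nH]c(=O)c2cc1Cl)C1CNCC1c1ccccn1`, gives 14 nM in this assay. Compound 2, `NC(C(=O)Nc1cc2cc[nH]c(=O)c2cc1Cl)c1cccc(Cl)c1`, gives 15 nM. These two numbers lie within the usual scatter of each other, so neither compound can be called the stronger inhibitor; compound 1 merely holds the lower of the two numbers, with compound 2 right beside it.

Compound 3, `O=C(Nc1cc2cc[nH]c(=O)c2cc1Cl)C1CNCC1c1ccc(Cl)cc1Cl`, has not yet been measured. It differs from compound 1 in one place: 2,4-dichlorophenyl in place of pyridin-2-yl on a saturated ring carbon. The shared core and the rest of compound 1 stay as they are, so the change is confined to the group on the saturated ring carbon.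

Going by the values given here, no measured pair shows what such an exchange does here. Still, a carbon-only ring carrying chlorine is already present in compound 2, which gives 15 nM, a number close to that of compound 1. On that ground the step from compound 1 to compound 3 in this assay is expected to be small, a 1.4-fold higher number from compound 1 to compound 3 (0.15 log units; within the scatter), with no clear direction beyond the scatter. Compound 3 is therefore estimated to give 20 nM, somewhere between 5 nM and 80 nM.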

Compound 3, half-maximal inhibitory concentration: 8 nM
The estimate for compound 3 lay 2.5-fold (0.40 log units) above the measured number, within the range that was stated.
By their numbers in this assay, from the lowest: compounds 3, 1 and 2 (each within the scatter of the next).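

Going by these compounds alone, this is the first pair that differs in one place only, so it isolates the group on the saturated ring carbon, which compounds 1 and 2 could not do because they differ in more than that group. In this assay the exchange of pyridin-2-yl for 2,4-dichlorophenyl gives a 1.8-fold lower number from compound 1 to compound 3 (0.24 log units; within the scatter) and so shows that this position accepts a carbon-only ring carrying two chlorines in place of a ring with a nitrogen, with no change that can be told from the scatter; the hydrogen-bond acceptor of pyridin-2-yl is therefore not needed for a number in this range. Nothing available here explains why two such different groups give such similar numbers.

The pair cannot separate the two chlorines from the change of ring, so plain phenyl or a phenyl with a single chlorine would be needed to show what each part contributes. Also open, from the compounds shown here alone, is how this position responds to a group of another kind, such as a carboxylic acid or an amine on the ring, or to a longer chain between the ring and the saturated ring carbon.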